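Heteroaryl exchange at the shared core: compound 4

A few compounds are considered here, and "the series" means these few. Any claim that something is new, unique, unknown or untested is made for them only; others in the source may bear on it.

Measured compounds:
compound 1, `COC(=O)c1nc(C(C)C)n(-c2ccc(F)cc2)n1`, > 100000 nM
compound 2, `CCCCc1nc(C(=O)OC)nn1-c1ccc(F)cc1`, > 100000 nM
compound 3, `COC(=O)c1nc(-c2ccoc2)n(-c2ccc(F)cc2)n1`, 9320 nM

In a functional assay on Jurkat cells (Homo sapiens) for inhibition, read by MTT assay, with a stated time of 72 h (on this read-out lower numbers stand for stronger inhibition of growth and higher numbers for weaker inhibition of growth), compound 1 gives > 100000 nM, which is a limit of the assay and not a number. Compound 2 also reaches only the limit > 100000 nM in this assay. Among the compounds with values here, compound 3 gives 9320 nM in this assay and so stands as the only compound of the three with a measured number. Compound 1 and compound 2 sit at the limit (the limit of > 100000 nM in this assay, at which 2 of the 3 values shown sit). The step from isopropyl to butyl, a step that the two limits leave unreadable from compound 1 to compound 2, cannot be read because both values sit at the limit. The two steps that bring in a heteroaryl group in place of an alkyl group, an at least 10-fold lower number from compound 1 to compound 3 (1.03 log units; beyond the scatter) and an at least 10-fold lower number from compound 2 to compound 3 (1.03 log units; beyond the scatter), are large.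

Compound 4, `COC(=O)c1nc(-c2ccc[nH]2)n(-c2ccc(F)cc2)n1`, differs from compound 3 by 1H-pyrrol-2-yl in place of furan-3-yl on an aromatic carbon. Within the data shown here, no measured step bears directly on this exchange of one five-membered heteroaryl for another; the large steps seen so far concern alkyl to heteroaryl only, and compound 4 keeps a heteroaryl group at that carbon. The step expected from this change is a 1.2-fold lower number from compound 3 to compound 4 (0.07 log units; within the scatter), none beyond the scatter. Compound 4 is therefore estimated at 8000 nM in this assay, with an expected range from 2000 nM to 40000 nM.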

Compound 4, concentration for 50% growth inhibition: 9010 nM
Beside the measured number, compound 4's estimate is 1.1-fold (0.05 log units) below it, and the stated range covers the measured number.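

In this assay, the exchange of furan-3-yl for 1H-pyrrol-2-yl gives a 1.0-fold lower number from compound 3 to compound 4 (0.01 log units; within the scatter), so at this aromatic carbon the change of hetero atom and point of attachment, with a hydrogen-bond acceptor leaving and a hydrogen-bond donor entering, produces no readable difference. The large alkyl-to-heteroaryl steps no longer rest on furan-3-yl alone, as 1H-pyrrol-2-yl gives an at least 11-fold lower number from compound 2 to compound 4 (1.04 log units; beyond the scatter) and an at least 11-fold lower number from compound 1 to compound 4 (1.04 log units; beyond the scatter). In both of these steps, the alkyl compound's value is a limit and not a number: the limit of > 100000 nM in this assay, at which 2 of the 4 values shown sit.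

Within the compounds shown, the two five-membered heteroaryl groups give values within the scatter of each other, so it remains open whether a phenyl or pyridin-3-yl group at this carbon would separate from them in this assay. On these data alone, it is also open whether the methoxycarbonyl group contributes to growth inhibition, a question that a carboxylic acid or a primary amide at that ring atom would address.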